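Side-chain swaps at the cytotoxicity limit

A few compounds are considered here, and "the series" means these few. Any claim that something is new, unique, unknown or untested is made for them only; others in the source may bear on it.

Compound 1 `CN(CCC#N)C[C@H]1CN(c2ccc(-n3cc(-c4ccccn4)cn3)c(F)c2)C(=O)O1`: > 400 ug/mL (a limit)
Compound 2 `O=C1O[C@@H](CSc2cccs2)CN1c1ccc(-n2cc(-c3ccccn3)cn2)c(F)c1`: > 400 ug/mL (a limit)

In an ADME assay on HEK293-A cells (Homo sapiens) for cytotoxicity, read by MTT assay, with a stated time of 48 h (a lower number here means a stronger inhibitor, a higher number a weaker inhibitor), compound 2 stands at > 400 ug/mL, which is a limit and not a number. Compound 3 `CN(C)S(=O)(=O)NC[C@H]1CN(c2ccc(-n3cc(-c4ccccn4)cn3)c(F)c2)C(=O)O1` has (dimethylsulfamoyl)amino in place of (thiophen-2-yl)sulfanyl on a saturated chain carbon bound to a saturated ring carbon. For the measured compounds named here, the one measured step is a step that the two limits leave unreadable from compound 1 to compound 2. That step, with the limit of > 400 ug/mL in this assay, at which 2 of the 2 values shown sit, gives no size to carry over, so no step beyond the scatter is expected in this assay. The expected step is a step that the limit leaves unreadable from compound 2 to compound 3. Compound 3 is estimated at 450 ug/mL, with an expected range of 220 ug/mL to 900 ug/mL.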

Compound 3, half-maximal inhibitory concentration: 249 ug/mL
For compound 3 the middle estimate is 1.8-fold (0.26 log units) above the measured one; low and high end bracket the measured number.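

In this assay, for the compounds shown here, (dimethylsulfamoyl)amino on a saturated chain carbon bound to a saturated ring carbon gives the first reading at this position that is a number, with compound 3 at 249 ug/mL. The change reads as an at least 1.6-fold lower number from compound 2 to compound 3 (0.20 log units; that floor lies within the scatter), and as an at least 1.6-fold lower number from compound 1 to compound 3 (0.20 log units; that floor lies within the scatter). The other two compounds remain limits, so neither step has a full size and the step between those two cannot be read: the limit of > 400 ug/mL in this assay, at which 2 of the 3 values shown sit.

On these data alone, whether a primary amine or a carboxylic acid at this position would also give a number stays open. So does the effect of a longer chain carrying the sulfamoyl group.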